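Trading Methoxy for Trifluoromethyl in a Cell Growth Assay

The compounds below may be only part of what the source reports. "The series", "measured", "known", "first", "only" and "open" are said of these compounds alone.

Of the compounds shown here, two have been tested in a functional assay on PC-3 cells (Homo sapiens) for inhibition, read by MTT assay, with a stated time of 24 h; on this read-out higher numbers stand for weaker inhibition and lower numbers for stronger inhibition. Compound 1 `CC(C)(C)/[N+]([O-])=C/c1cn(-c2ccccc2)nn1` gives 15400 nM, and compound 2 `COc1ccc(-n2cc(/C=[N+](\[O-])C(C)(C)C)nn2)cc1` gives 23800 nM. Among the measured compounds shown here, the only step measured so far, a 1.5-fold higher number from compound 1 to compound 2 (0.19 log units; within the scatter), lies within the scatter, so compound 2 stands at the higher of the two numbers without being separable from compound 1. Compound 3 `CC(C)(C)/[N+]([O-])=C/c1cn(-c2ccc(C(F)(F)F)cc2)nn1` differs from compound 2 by trifluoromethyl in place of methoxy on an aromatic carbon, a trifluoromethyl in place of methoxy on an aromatic carbon, para to a large group. For the measured compounds named here, no measured step involves a trifluoromethyl, and the single measured step, which also altered this carbon, stayed within the scatter. The expectation is therefore a step no larger than the scatter, a 1.3-fold lower number from compound 2 to compound 3 (0.10 log units; within the scatter). Compound 3 is expected to give about 19000 nM in this assay, with a range from 6000 nM to 60000 nM.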

Compound 3, half-maximal inhibitory concentration: 42000 nM
The estimate for compound 3 lay 2.2-fold (0.34 log units) below the measured number; the measured number falls inside the stated range.
By their numbers in this assay, from the lowest: compounds 1, 2 and 3 (each within the scatter of the next, the first and the last beyond it).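

In this assay, this carbon, on a six-membered aromatic ring of carbon only and para to a large group, now gives a change that clears the usual scatter: trifluoromethyl in place of hydrogen brings modestly weaker inhibition (a 2.7-fold higher number from compound 1 to compound 3 (0.44 log units; beyond the scatter)). Methoxy and trifluoromethyl at this carbon still cannot be told apart (a 1.8-fold higher number from compound 2 to compound 3 (0.25 log units; within the scatter)), so the two substituted compounds can be separated from each other by no measured step, and only trifluoromethyl has moved the number clearly away from hydrogen. Nothing available here explains why this replacement has this effect.

The three compounds leave open how an amine, a carboxylic acid or a longer chain on this carbon would behave. They also leave open whether trifluoromethyl on another carbon of the same ring would give a similar step.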